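One added methyl on the way to compound 3

The source may report more compounds than this note shows. Statements on the series, on what has been measured and on what is new or still open speak of the compounds shown alone.

Compound 1 `CCN(CC)C(=O)c1c(NC(=O)c2ccco2)sc2c1CCCC2`: > 30000 nM (a limit)
Compound 2 `CCN(CC)C(=O)c1c(NC(=O)c2cccs2)sc2c1CCC(C)C2`: 6100 nM

Within the data shown here, in a functional assay on A549 cells (Homo sapiens) for cytotoxicity, with a stated time of 60 h (on this read-out lower numbers stand for an effect already at smaller amounts and higher numbers for an effect only at larger amounts of compound), compound 2 gives 6100 nM, and this is the only actual number available so far. Compound 1 is recorded only as a limit of this assay, > 30000 nM. Compound 2 therefore has no measured neighbour that would anchor a comparison.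

Compound 3 `CCN(CC)C(=O)c1c(NC(=O)c2cccs2)sc2c1CCC(C)(C)C2` differs from compound 2 in one place: methyl in place of hydrogen on a saturated ring carbon. Among the measured compounds shown here, no step between measured compounds shows what such a change does in this assay, so no shift beyond the usual scatter is expected, and no firm direction can be given. The expected step is a 1.4-fold lower number from compound 2 to compound 3 (0.13 log units; within the scatter). For compound 3 the estimated value is 4500 nM, with an expected range of 1800 nM to 12000 nM.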

Compound 3, half-maximal effective concentration: 24000 nM
For compound 3 the middle estimate is 5.3-fold (0.73 log units) below the measured one; the whole stated range lies below it.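

In this assay, among these compounds, methyl in place of hydrogen on a saturated ring carbon proves not to be a neutral change: it gives a 3.9-fold higher number from compound 2 to compound 3 (0.59 log units; beyond the scatter), the first step between measured compounds in this account, and it points towards an effect only at larger amounts of compound. This saturated ring carbon of the six-membered ring therefore bears on the read-out, which compound 2 alone, without a measured neighbour, could not show. A further upward step of this size would no longer give a number, only a limit such as the one recorded for compound 1: the limit of > 30000 nM in this assay, at which 1 of the 3 values shown sits.

One step sets no pattern, and the compounds shown do not tell why the number rises. They also leave open what a longer chain such as ethyl, a hydroxyl or an amine on this ring carbon would do.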